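Trimming the Amide Substituent from Aryl to Methyl

The compounds below may be only part of what the source reports. "The series", "measured", "known", "first", "only" and "open" are said of these compounds alone.

Compound 2 `Cc1ccc(NC(=O)c2c(NO)cc(-c3ccccc3)oc2=O)cc1` carries a 4-methylphenyl group on its amide nitrogen. In an ADME assay on Huh-7 cells (Homo sapiens) for cytotoxicity, read by a luciferase reporter and WST assay, with a stated time of 3 days (on this read-out lower numbers stand for higher toxicity in this test and higher numbers for lower toxicity in this test), compound 2 gives only a limit, > 20000 nM. Its neighbour compound 1 `Cc1cccc(NC(=O)c2c(NO)cc(-c3ccccc3)oc2=O)c1` likewise gives only a limit in this assay, > 20000 nM. The step that the two limits leave unreadable from compound 1 to compound 2 therefore cannot be read, because of the limit of > 20000 nM in this assay, at which 2 of the 2 values shown sit. Compound 3 `CNC(=O)c1c(NO)cc(-c2ccccc2)oc1=O` differs from compound 2 by methyl in place of 4-methylphenyl on an amide-type nitrogen. No measured step bears directly on this change; the only step shown is the unreadable one from compound 1 to compound 2, and both values sit at the limit. Compound 3 is therefore expected to remain at or near that limit in this assay. The estimated step that the limit leaves unreadable from compound 2 to compound 3 is expected to be none beyond the scatter. Compound 3 is estimated at 30000 nM, with a range from 12000 nM to 80000 nM.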

Compound 3, half-maximal cytotoxic concentration: > 20000 nM
Compound 3: no number, only a limit; the forecaster's own chance of this, stated with the estimate: 80%; the middle value is on the limit's open side.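

Like compound 1 and compound 2, compound 3 gives only a limit in this assay, so no step among these compounds can be read: the limit of > 20000 nM in this assay, at which 3 of the 3 values shown sit. The compounds shown leave open whether methyl, 3-methylphenyl and 4-methylphenyl on the amide-type nitrogen differ at all in this assay.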